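Side-chain swap on the benzyl ester of compound 3

The source may hold more compounds than are shown below. What is called first, only, known or untested is meant among the compounds shown, and "the series" means these compounds.

Of the compounds shown here, three have been tested in a functional assay on the whole organism with Mus musculus as the target, with a stated time of 90 min, at a dose of 25 umol/kg by the oral route; a higher number here means a stronger effect of the compound at the dose given, a lower number a weaker effect. Compound 1 `Clc1nc(NC2CC2)c2ncn(C3CCCCO3)c2n1` gives 11.9%, compound 2 `CCOC(=O)CN(c1nc(Cl)nc2c1ncn2C1CCCCO1)C1CC1` gives 13%, and compound 3 `NC(=O)C[C@H](NC(=O)CN(c1nc(Cl)nc2c1ncn2C1CCCCO1)C1CC1)C(=O)OCc1ccccc1` gives 35%, the highest of the three numbers, with compound 2 and compound 1 both lower beyond the scatter. Among the compounds with values here, the only measured step, a number 1.1 percentage points higher from compound 1 to compound 2 (within the scatter), concerns the nitrogen on the aromatic ring and lies within the scatter.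

Compound 4 `CC[C@H](C)[C@H](NC(=O)CN(c1nc(Cl)nc2c1ncn2C1CCCCO1)C1CC1)C(=O)OCc1ccccc1` differs from compound 3 in sec-butyl in place of carbamoylmethyl on a saturated chain carbon bound to an amide-type nitrogen and a carbonyl carbon. No measured step touches this part of the molecule, so nothing shown bears directly on it. The step from compound 1 to compound 2 only indicates that a change elsewhere left the read-out essentially unchanged. An expectation for compound 4 therefore rests on compound 3 alone, its value 35% being the reference, with wide uncertainty and no firm direction. Compound 4 is estimated to give 30%, between 12% and 50%, so that the expected step of a number 5 percentage points lower from compound 3 to compound 4 (within the scatter) stays close to the scatter.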

Compound 4, a percentage reported as activity, at one dose (the size of the read-out at that dose, not a potency): 22.6%
Estimate against measurement, compound 4: 7.4 percentage points above, and the stated range covers the measured number.
By their numbers in this assay, from the lowest: compounds 1, 2 and 4 (each within the scatter of the next, the first and the last beyond it); then compound 3.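

At this saturated chain carbon bound to an amide-type nitrogen and a carbonyl carbon, the side chain does affect the read-out in this assay: sec-butyl in place of carbamoylmethyl gives a number 12.4 percentage points lower from compound 3 to compound 4 (beyond the scatter) in this first step shown at this place. The change keeps the count of four heavy atoms but swaps the nitrogen and oxygen of carbamoylmethyl, with its hydrogen-bond donor and acceptor, for carbon alone, and this single pair cannot show which of these differences matters. Nothing measured accounts for the lower number.

From the compounds shown here alone, whether the terminal amide itself is needed remains open, and a carboxylic acid, an aminobutyl chain or a plain methyl at this carbon would test that. Going by these compounds, it is also open whether the benzyl ester must stay, or whether the free carboxylic acid would serve in its place.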